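This account rests on a few compounds, and the source may have more. Where it says the series, first, only, none or still open, it means among the compounds named here.

Compound 1 `COc1ccc2nc(C)cc(OCC(=O)Nc3cc(C)cc(C)c3)c2c1` gives 20000 nM in a toxicity assay on HepG2 cells (Homo sapiens) for inhibition, read by CellTiter-Glo, with a stated time of 48 h; a lower number here means a stronger inhibitor, a higher number a weaker inhibitor. Compound 2 `CCOc1ccc2nc(C)cc(OCC(=O)Nc3cc(C)cc(C)c3)c2c1` reaches only the limit > 100000 nM in this assay. Compound 3 `Cc1cc(C)cc(NC(=O)COc2cc(C)nc3ccc(OCc4ccccc4)cc23)c1` likewise reaches only the limit > 100000 nM in this assay.

For the measured compounds named here, compound 1 thus stands as the sole measured number here; the other two values are limits, (the limit of > 100000 nM in this assay, at which 2 of the 3 values shown sit). Compound 4 `COc1ccc2nc(C)cc(OCC(=O)Nc3ccc(Br)c(C)c3)c2c1` differs from compound 1 in one place: 4-bromo-3-methylphenyl in place of 3,5-dimethylphenyl on an amide-type nitrogen. The measured steps concern a different part of the molecule, the saturated chain carbon bound to an oxygen on the aromatic ring: an at least 5.0-fold higher number from compound 1 to compound 2 (0.69 log units; beyond the scatter) and an at least 5.0-fold higher number from compound 1 to compound 3 (0.69 log units; beyond the scatter). Going by the values given here, neither touches the amide-type nitrogen, and no measured step informs this change. A step of a 1.5-fold higher number from compound 1 to compound 4 (0.18 log units; within the scatter) is therefore expected, within the scatter. Compound 4 is estimated at 30000 nM, from 8000 nM to 100000 nM.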

Compound 4, half-maximal inhibitory concentration: 15900 nM
For compound 4 the middle estimate is 1.9-fold (0.28 log units) above the measured one; the range from low to high includes it.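

Putting 4-bromo-3-methylphenyl in place of 3,5-dimethylphenyl on the amide-type nitrogen gives a 1.3-fold lower number from compound 1 to compound 4 (0.10 log units; within the scatter), so in this assay this swap cannot be told apart from no change. This is the only step shown at this position, and compound 4, unlike the compounds changed on the saturated chain carbon, gives a measured number rather than a limit: the limit of > 100000 nM in this assay, at which 2 of the 4 values shown sit.

Only this one swap on the amide-type nitrogen is shown. On these data alone, whether a phenyl ring carrying an amine or a carboxylic acid would move the reading beyond the scatter remains open.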